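This account rests on a few compounds, and the source may have more. Where it says the series, first, only, none or still open, it means among the compounds named here.

Working notes on the series, metabolic stability.

For the measured compounds named here, compound 1 `COc1cc(-c2nccc3[nH]c(-c4cccc5[nH]ccc45)nc23)cc(OC)c1OC` stands highest of the two compounds measured so far in an ADME assay (liver, Mus musculus) for metabolic stability, read by LC-MS, using microsomes, tested at 2 uM; a higher number here means that the compound lasts longer, a lower number that the compound disappears faster; in this assay compound 1 gives 0.175 h. Compound 2 `COc1cc(-c2nccc3ccc(-c4ccc5[nH]ccc5c4)cc23)cc(OC)c1OC`, built on a different core, gives in this assay a half-life of 0.035 h, a gap to compound 1 that lies beyond the usual scatter of this kind of measurement. Going by the values given here, no pair of measured compounds differs in a single place, so nothing yet shows how a small change in the substituent on the core of compound 1 moves the number.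

Compound 3 `COc1cc(-c2nccc3[nH]c(-c4ccc5cc[nH]c5c4)nc23)cc(OC)c1OC` keeps the core of compound 1 and differs from it only in 1H-indol-6-yl in place of 1H-indol-4-yl on an aromatic carbon. The same atoms are present, joined differently. Among the compounds with values here, with no measured pair of this kind to lean on, the step from compound 1 to compound 3 is expected to be small, a 1.2-fold lower number from compound 1 to compound 3 (0.07 log units; within the scatter), in no firm direction and probably not beyond the scatter. Compound 3 is therefore expected to give about 0.15 h in this assay, in a range from 0.06 h to 0.4 h.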

Compound 3, half-life: 0.462 h
Estimate against measurement, compound 3: 3.1-fold (0.49 log units) below; measured number above the stated range.
By their numbers in this assay, from the lowest: compound 2; then compound 1; then compound 3.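

In this assay, for the compounds shown here, the exchange of 1H-indol-4-yl for 1H-indol-6-yl, on the aromatic carbon between two ring nitrogen atoms, gives a 2.6-fold higher number from compound 1 to compound 3 (0.42 log units; beyond the scatter) and provides the first comparison that differs in one place. The atoms stay the same and only the way the indole is joined changes, yet the step lies beyond the scatter, so on the shared core the half-life at this position is sensitive to the point of attachment of the indole, although the step is modest and rests on this one pair. Nothing measured on these compounds bears on why the number moves.

Still open, on these data alone, is how 1H-indol-7-yl at the same position, or a fluorine atom or a nitrile on the 1H-indol-6-yl ring, would move the half-life from the level of compound 3. Going by these compounds alone, also open is whether the same exchange of indole attachment would give a step of similar direction and size on a core other than the one shared by compound 1 and compound 3.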